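The source may report more compounds than this note shows. Statements on the series, on what has been measured and on what is new or still open speak of the compounds shown alone.

Measured compounds in a functional assay on FM3A cells (Mus musculus) for inhibition, read by cell counting, with a stated time of 2 days; on this read-out higher numbers stand for weaker inhibition and lower numbers for stronger inhibition:
- compound 1 `Nc1cccc(-c2cn3nc(Cc4ccc(Cl)cc4)sc3n2)c1`: 6000 nM
- compound 2 `C=C(Br)C(=O)Nc1cccc(-c2cn3nc(Cc4ccc(OC)cc4)sc3n2)c1`: 850 nM
- compound 3 `COc1cccc(Cc2nn3cc(-c4cccc(N)c4)nc3s2)c1`: 10000 nM

Compound 3 gives the highest number of the three in this assay. Its nearest neighbour is compound 1, whose number is lower by an amount that stays within the scatter, so no order between compound 3 and compound 1 can be read from these two values. Compound 2 stands furthest from compound 3, with a number lower by a margin that is beyond the scatter.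

Compound 4 `COc1ccc(Cc2nn3cc(-c4cccc(N)c4)nc3s2)cc1` differs from compound 3 as follows: 4-methoxyphenyl in place of 3-methoxyphenyl on a saturated chain carbon bound to an aromatic carbon

Within the data shown here, one measured step bears on this position: a 1.7-fold higher number from compound 1 to compound 3 (0.22 log units; within the scatter). That step swaps one aryl group for another on the same saturated chain carbon and stays within the scatter, so the series gives no sign that a change at this site moves the number beyond the scatter. The expectation for this assay is therefore a step of no size beyond the scatter, in either direction, meaning an expected 1.4-fold lower number from compound 3 to compound 4 (0.15 log units; within the scatter).

Compound 4 is thus estimated at 7000 nM in this assay, with a range from 2500 nM to 20000 nM.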

Compound 4, half-maximal inhibitory concentration: 100000 nM
Compound 4: the middle estimate sits 14-fold (1.15 log units) below what was measured; the whole stated range lies below it.
By their numbers in this assay, from the lowest: compound 2; then compounds 1 and 3 (each within the scatter of the next); then compound 4.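

In this assay the change to 4-methoxyphenyl in place of 3-methoxyphenyl on the saturated chain carbon gives a 10-fold higher number from compound 3 to compound 4 (1.00 log units; beyond the scatter) and so shows that this site can respond beyond the scatter to a change that keeps the same atoms, which the earlier step of a 1.7-fold higher number from compound 1 to compound 3 (0.22 log units; within the scatter) did not reveal. Methoxy in place of chloro on an aromatic carbon now gives a 17-fold higher number from compound 1 to compound 4 (1.22 log units; beyond the scatter) as well, while hydrogen in place of (1-bromoethenyl)carbonyl on the nitrogen gives a 120-fold higher number from compound 2 to compound 4 (2.07 log units; beyond the scatter) and places compound 4 highest of the four. No measured evidence available here accounts for these steps.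

Still open, as far as these compounds go, is whether (1-bromoethenyl)carbonyl on the nitrogen gives a similar step with 3-methoxyphenyl or 4-chlorophenyl on the chain carbon. Also open, from the compounds shown here alone, is whether 4-ethoxyphenyl or 4-hydroxyphenyl at this site would stand with compound 4 or with compound 3.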